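A carbamate in place of the neopentyl ester

The source may hold more compounds than are shown below. What is called first, only, known or untested is meant among the compounds shown, and "the series" means these compounds.

Compound 3 `COc1cc(C(=O)N2CCN(C(=O)c3cc(OC)c(OC)c(OC)c3)C(COC(=O)CC(C)(C)C)C2)cc(OC)c1OC` stands at 120 nM in a functional assay (Oryctolagus cuniculus) for inhibition of platelet-activating factor receptor (Cavia porcellus) (on this read-out lower numbers stand for stronger inhibition and higher numbers for weaker inhibition), the lower of the two single numbers shown; compound 1 `CCCC(=O)OCC1CN(C(=O)c2cc(OC)c(OC)c(OC)c2)CCN1C(=O)c1cc(OC)c(OC)c(OC)c1` gives 420 nM, while compound 2 `CCC(CC)C(=O)OCC1CN(C(=O)c2cc(OC)c(OC)c(OC)c2)CCN1C(=O)c1cc(OC)c(OC)c(OC)c1` gives 70 nM; 40 nM; 60 nM (3 entries). Among the compounds with values here, the one measured step, a 3.5-fold lower number from compound 1 to compound 3 (0.54 log units; beyond the scatter), is modest. Compound 4 `CCC(C)(C)NC(=O)OCC1CN(C(=O)c2cc(OC)c(OC)c(OC)c2)CCN1C(=O)c1cc(OC)c(OC)c(OC)c1` differs from compound 3 by (1,1-dimethylpropyl)amino in place of neopentyl on a carbonyl carbon. Within the data shown here, no measured step exchanges an ester for a carbamate, and the spread in the several entries of compound 2 in this assay, 70 nM; 40 nM; 60 nM (3 entries) shows how far repeat values can wander. Among the measured compounds shown here, the single measured step bears on this change only loosely, so compound 4 is expected to land close to compound 3. The step to compound 4 is therefore expected to be a 1.3-fold higher number from compound 3 to compound 4 (0.10 log units; within the scatter), not clearly beyond the scatter. Compound 4 is estimated at 150 nM, between 50 nM and 450 nM.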

Compound 4, half-maximal inhibitory concentration: 320 nM
Compound 4: middle estimate off by 2.1-fold (0.33 log units), on the low side; the measured number falls inside the stated range.
By their numbers in this assay, from the lowest: compound 3; then compounds 4 and 1 (each within the scatter of the next).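

Placing (1,1-dimethylpropyl)amino on this carbonyl carbon instead of neopentyl weakens inhibition, with a 2.7-fold higher number from compound 3 to compound 4 (0.43 log units; beyond the scatter). Set against the propyl ester, the same carbamate gives a 1.3-fold lower number from compound 1 to compound 4 (0.12 log units; within the scatter), so the advantage of compound 3 over compound 1 does not carry over to compound 4. Repeat values in this series can wander, as one compound shows: the several entries of compound 2 in this assay, 70 nM; 40 nM; 60 nM (3 entries)

The compounds shown do not separate the added nitrogen from the change in the carbon branching. As far as these compounds go, it also remains open how a cyclohexylamino carbamate or an amide would behave at this place.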